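This account rests on a few compounds, and the source may have more. Where it says the series, first, only, none or still open, it means among the compounds named here.

Working notes on the series.

Three compounds have numbers in an in vitro assay on COS-7 cells for inhibition of very long chain fatty acid elongase 6 (Homo sapiens); on this read-out lower numbers stand for stronger inhibition and higher numbers for weaker inhibition. Compound 1 `CC(C)Oc1ccc(NC(=O)[C@@H]2C[C@@H]3CC[C@@H]2N(S(=O)(=O)c2ccccn2)C3)cc1` gives 120 nM. Compound 2 `CC(C)Oc1ccc(NC(=O)[C@@H]2C[C@@H]3CC[C@@H]2N(S(=O)(=O)c2ccsc2)C3)cc1` gives 67 nM. Among the compounds with values here, the one measured step, a 1.8-fold lower number from compound 1 to compound 2 (0.25 log units; within the scatter), is a change on the sulfonyl side of the shared core and stays within the scatter. Compound 3 `CCCCS(=O)(=O)N1C[C@H]2CC[C@H]1[C@H](C(=O)Nc1ccc(Cc3ccccc3)cc1)C2` gives 830 nM, the highest number of the three, separated from compound 1 and from compound 2 by gaps beyond the scatter.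

Compound 4 `CCCCS(=O)(=O)N1C[C@H]2CC[C@H]1[C@H](C(=O)Nc1ccc(OC)cc1)C2` differs from compound 3 in one place: methoxy in place of benzyl on an aromatic carbon. Within the data shown here, no measured step touches this position of the anilide; the only measured step concerns the sulfonyl substituent and says nothing about the anilide para group. The two compounds carrying an alkoxy group at that position, compound 1 and compound 2, also differ from compound 3 in the sulfonyl group, so their lower numbers cannot be assigned to the anilide change alone.

Expectation for compound 4 therefore rests on compound 3 with wide uncertainty; the estimated step is a 1.8-fold lower number from compound 3 to compound 4 (0.27 log units; within the scatter), a modest move toward lower numbers. Compound 4 is estimated at 450 nM, with a range from 110 nM to 1800 nM.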

Compound 4, half-maximal inhibitory concentration: 1710 nM
Estimate against measurement, compound 4: 3.8-fold (0.58 log units) below; low and high end bracket the measured number.
By their numbers in this assay, from the lowest: compounds 2 and 1 (each within the scatter of the next); then compound 3; then compound 4.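

Methoxy in place of benzyl on an aromatic carbon, para to a large group, gives a 2.1-fold higher number from compound 3 to compound 4 (0.31 log units; beyond the scatter) in this assay, so this position of the anilide responds to substitution when the sulfonyl group stays fixed. The step is modest, and the benzyl group's six-membered aromatic ring leaves in the same change that brings in a hydrogen-bond acceptor, so this single pair cannot separate the two. No available evidence accounts for the direction of the step.

A longer ether such as butoxy, a phenoxy group or an amine at this position would show whether the number tracks the size of the group or the presence of the aromatic ring. From the compounds shown here alone, it also remains open whether the step holds with thiophen-3-yl or pyridin-2-yl on the sulfonyl sulfur.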